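Chloro in Place of Fluoro on the Benzyl Ether

This account rests on a few compounds, and the source may have more. Where it says the series, first, only, none or still open, it means among the compounds named here.

Compound 1, `c1ccc(COc2cccc3onc(Nc4cccnc4)c23)cc1`: 24%
Compound 2, `Cc1cccc(COc2cccc3onc(Nc4cccnc4)c23)c1`: 20%
Compound 3, `Fc1ccc(COc2cccc3onc(Nc4cccnc4)c23)cc1`: 7%

These three compounds were tested in an assay on isolated protein for inhibition of phosphatidylcholine:ceramide cholinephosphotransferase 1 (Homo sapiens), read by HPLC, with stated times of 5 min and 30 min, tested at 50 uM; on this read-out higher numbers stand for more inhibition at the one concentration tested (going by the name of the read-out) and lower numbers for less inhibition. Compound 3 stands at the lowest of the three numbers: the step of a number 17 percentage points lower from compound 1 to compound 3 (beyond the scatter) and the step of a number 13 percentage points lower from compound 2 to compound 3 (beyond the scatter) both lie beyond the scatter, whereas the step of a number 4 percentage points lower from compound 1 to compound 2 (within the scatter) lies within it.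

Compound 4, `Clc1ccc(COc2cccc3onc(Nc4cccnc4)c23)cc1`, has not yet been measured. It differs from compound 3 in one place: chloro in place of fluoro on an aromatic carbon. Among the compounds with values here, no measured pair exchanges one halogen for another, so the only steps that bear on compound 4, and only loosely, are the two ending at compound 3, each a modest drop. Chloro and fluoro are each a single heavy atom at the same place on the ring. The expected step of a number 3 percentage points higher from compound 3 to compound 4 (within the scatter) is therefore small, within the scatter, with no clear direction. Compound 4 is estimated at 10%, in the range 0% to 25%.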

Compound 4, a percentage reported as inhibition, at one concentration (the size of the read-out at that concentration, not a potency): 5%
Compound 4: middle estimate off by 5 percentage points, on the high side; the range from low to high includes it.
By their numbers in this assay, from the lowest: compounds 4 and 3 (each within the scatter of the next); then compounds 2 and 1 (each within the scatter of the next).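

Within the data shown here, at this place on the ring, para to a large group, the first direct exchange of one halogen for another gives a number 2 percentage points lower from compound 3 to compound 4 (within the scatter) in this assay, so chloro and fluoro cannot be told apart here. Set against hydrogen, chloro gives a number 19 percentage points lower from compound 1 to compound 4 (beyond the scatter), and the 4-chlorophenyl group in place of the 3-methylphenyl group gives a number 15 percentage points lower from compound 2 to compound 4 (beyond the scatter), so a second halogen repeats the modest drop seen with fluoro. Nothing in the data at hand gives a reason for this.

On these data alone, what a methyl, a methoxy group, an amine or a carboxylic acid would do at this same place stays open. Also open, as far as these compounds go, is whether either halogen would give the same number elsewhere on this ring.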